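This account rests on a few compounds, and the source may have more. Where it says the series, first, only, none or still open, it means among the compounds named here.

Working notes on the series.

Compound 1 `OC[C@H]1OC(n2cnc3c(-c4cc[nH]c4)ncnc32)[C@H](O)[C@@H]1O` gives 3200 nM in a functional assay on HL-60 cells (Homo sapiens) for inhibition; a lower number here means a stronger inhibitor, a higher number a weaker inhibitor. For the measured compounds named here, compound 2 `OC[C@H]1OC(n2cnc3c(-c4ccccn4)ncnc32)[C@H](O)[C@@H]1O` gives 5600 nM in this assay; the step of a 1.8-fold higher number from compound 1 to compound 2 (0.24 log units; within the scatter) is the only measured step so far. Compound 2 therefore stands alongside compound 1, the two numbers lying within the scatter of each other, so neither can be called the stronger or weaker of the pair.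

The next compound, compound 3 `OC[C@H]1OC(n2cnc3c(-c4ccc(F)cc4)ncnc32)[C@H](O)[C@@H]1O`, differs from compound 2 by 4-fluorophenyl in place of pyridin-2-yl on an aromatic carbon. Going by the values given here, no measured step covers this exchange; the one step on record, a 1.8-fold higher number from compound 1 to compound 2 (0.24 log units; within the scatter), replaces a different five-membered ring at the same position and stays within the scatter. Nothing on record points to a shift beyond the scatter in this assay in either direction, so the expected step is a 1.1-fold lower number from compound 2 to compound 3 (0.05 log units; within the scatter). Compound 3 is thus estimated at 5000 nM in this assay, within a range of 1500 nM to 16000 nM.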

Compound 3, half-maximal inhibitory concentration: 6300 nM
Estimate against measurement, compound 3: 1.3-fold (0.10 log units) below; low and high end bracket the measured number.
By their numbers in this assay, from the lowest: compounds 1, 2 and 3 (each within the scatter of the next).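

The exchange of pyridin-2-yl for 4-fluorophenyl at this aromatic carbon in this assay gives a 1.1-fold higher number from compound 2 to compound 3 (0.05 log units; within the scatter), so removing the ring nitrogen and its hydrogen-bond acceptor while adding fluorine leaves the numbers within the scatter. Set against 1H-pyrrol-3-yl, 4-fluorophenyl gives a 2.0-fold higher number from compound 1 to compound 3 (0.29 log units; within the scatter), so the three aromatic rings, five-membered or six-membered, with or without a ring hetero atom, all lie within the scatter of each other at this place. No supporting evidence is available to explain this result.

Still open, from the compounds shown here alone, is whether a group of another kind at this carbon, such as an amine, a carboxylic acid or a longer alkyl chain, would move the number beyond the scatter. Also open, going by these compounds, is how unsubstituted phenyl compares with 4-fluorophenyl.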